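Replacing the ((chloromethyl)carbonyl)amino group of compound 2

The source may report more compounds than this note shows. Statements on the series, on what has been measured and on what is new or still open speak of the compounds shown alone.

In a functional assay on HT-29 cells (Homo sapiens) for antiproliferative activity, with a stated time of 48 h (on this read-out higher numbers stand for weaker inhibition and lower numbers for stronger inhibition), compound 1 (`CCCCCc1cccc(NC(=O)NC(=O)CCl)c1`) gives 8400 nM and compound 2 (`CCCCC(OC)c1cccc(NC(=O)NC(=O)CCl)c1`) gives 10000 nM so the two stand level within the scatter. Compound 3 (`C=CC(=O)Nc1cccc(C(CCCC)OC)c1`) differs from compound 2 by vinyl in place of ((chloromethyl)carbonyl)amino on a carbonyl carbon. Among the compounds with values here, the one measured step (a 1.2-fold higher number from compound 1 to compound 2 (0.08 log units; within the scatter)) is a methoxy change on the chain, so no measured step bears directly on this exchange. A moderate rise in the number is only a tentative expectation, and the expected step is a 2.5-fold higher number from compound 2 to compound 3 (0.40 log units; beyond the scatter) with wide uncertainty. The estimate for compound 3 is 25000 nM with 8000 nM and 80000 nM as the expected ends of its range.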

Compound 3, half-maximal inhibitory concentration: 40000 nM
Estimate against measurement, compound 3: 1.6-fold (0.20 log units) below; the range from low to high includes it.
By their numbers in this assay, from the lowest: compounds 1 and 2 (each within the scatter of the next); then compound 3.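

In this assay vinyl in place of ((chloromethyl)carbonyl)amino on a carbonyl carbon gives a 4.0-fold higher number from compound 2 to compound 3 (0.60 log units; beyond the scatter) and is the only step shown that lies beyond the scatter, so this position responds where the methoxy change on the chain did not. The exchange removes a hydrogen-bond donor, a hydrogen-bond acceptor and the chlorine together, so the compounds shown cannot separate these parts. No measurement offered here accounts for the step. Going by these compounds, it remains open whether a methyl or an aminomethyl group on this carbonyl carbon would stand nearer compound 2 or compound 3. On these data alone, the same exchange on compound 1 is also open.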